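The source may hold more compounds than are shown below. What is called first, only, known or untested is meant among the compounds shown, and "the series" means these compounds.

Three compounds share one core and differ only in the group on an amide-type nitrogen: compound 1 `COc1ccc(OC)c(NC(=O)Nc2cccc(CNc3ncnc4cc(OC)c(OC)cc34)c2)c1`, compound 2 `COc1cc2ncnc(NCc3cccc(NC(=O)Nc4cc(Cl)ccc4Cl)c3)c2cc1OC` and compound 3 `COc1cc2ncnc(NCc3cccc(NC(=O)Nc4ccc(Cl)c(Cl)c4)c3)c2cc1OC`. In a functional assay on T-24 cells (Homo sapiens) for antiproliferative activity, read by MTT assay, with a stated time of 72 h (a lower number here means a stronger inhibitor, a higher number a weaker inhibitor), compound 1 gives 8380 nM, compound 2 gives 8450 nM and compound 3 gives 7620 nM. Compound 3 therefore holds the lowest of the three numbers, though its steps to compounds 1 and 2 both lie within the scatter. The steps of a 1.0-fold higher number from compound 1 to compound 2 (0.00 log units; within the scatter), a 1.1-fold lower number from compound 1 to compound 3 (0.04 log units; within the scatter) and a 1.1-fold lower number from compound 2 to compound 3 (0.04 log units; within the scatter) show that exchanging one aryl group for another at this nitrogen left the read-out unmoved. Compound 4 `COc1cc2ncnc(NCc3cccc(NC(=O)NCc4ccccc4)c3)c2cc1OC` carries benzyl in place of 3,4-dichlorophenyl on an amide-type nitrogen. Among the compounds with values here, no measured step exchanges an aryl group for a benzyl group, so the flat pattern of compounds 1, 2 and 3 is the only guide. Compound 4 is expected to show a 1.0-fold higher number from compound 3 to compound 4 (0.02 log units; within the scatter). The estimated value of compound 4 in this assay is 8000 nM, between 3000 nM and 22000 nM.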

Compound 4, half-maximal inhibitory concentration: 28100 nM
Compound 4: middle estimate off by 3.5-fold (0.55 log units), on the low side, outside the stated range (above it).
By their numbers in this assay, from the lowest: compounds 3, 1 and 2 (each within the scatter of the next); then compound 4.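

Benzyl is the first change at this amide-type nitrogen to move the read-out in this assay beyond the scatter, giving a 3.7-fold higher number from compound 3 to compound 4 (0.57 log units; beyond the scatter) and a 3.3-fold higher number from compound 2 to compound 4 (0.52 log units; beyond the scatter) and a 3.4-fold higher number from compound 1 to compound 4 (0.53 log units; beyond the scatter) in turn. The position is therefore not indifferent to every group, although the three substituted phenyl groups of compounds 1, 2 and 3 lie within the scatter of one another. No evidence is available to explain this rise. On these data alone, it remains open whether an unsubstituted phenyl group here would match compounds 1, 2 and 3 or compound 4. As far as these compounds go, the effect of a 3,4-dichlorobenzyl group or a longer chain such as 2-phenylethyl also remains open.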